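The source may hold more compounds than are shown below. What is called first, only, known or untested is meant among the compounds shown, and "the series" means these compounds.

Within the data shown here, in an assay on CHO cells for displacement of a labelled ligand from D(4) dopamine receptor (Homo sapiens), read by radioligand binding (on this read-out lower numbers stand for stronger inhibition and higher numbers for weaker inhibition), compound 3 `O=C(NCCCN1CCN(c2ccc(Cl)cc2)CC1)NN(Cc1ccc(F)cc1)c1ccccc1` gives 17 nM, numerically the highest of the three numbers so far, though within the scatter of compound 2 `O=C(NCCCN1CCN(c2ccc(Br)cc2)CC1)NN(Cc1ccccc1)c1ccccc1` at 14 nM and of compound 1 `O=C(NCCCN1CCN(c2ccc(Cl)cc2)CC1)NN(Cc1ccccc1)c1ccccc1` at 9.7 nM. Compound 4 `O=C(NCCCN1CCN(c2ccc(Br)cc2)CC1)NN(Cc1ccc(F)cc1)c1ccccc1` differs from compound 3 by bromo in place of chloro on an aromatic carbon. The same exchange has been seen once in this assay: a 1.4-fold higher number from compound 1 to compound 2 (0.16 log units; within the scatter). The other measured step, a 1.8-fold higher number from compound 1 to compound 3 (0.24 log units; within the scatter), concerns the fluoro and does not bear on this change. Among the measured compounds shown here, from the one relevant step, the shift expected in this assay from compound 3 to compound 4 is small, estimated as a 1.4-fold higher number from compound 3 to compound 4 (0.15 log units; within the scatter), toward a slightly higher number and not beyond the scatter. Compound 4 is therefore expected to give about 24 nM, with a range from 12 nM to 48 nM.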

Compound 4, inhibition constant: 46 nM
Compound 4: the middle estimate sits 1.9-fold (0.28 log units) below what was measured; the range from low to high includes it.
By their numbers in this assay, from the lowest: compounds 1, 2 and 3 (each within the scatter of the next); then compound 4.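

In this assay, bromo in place of chloro now gives a 2.7-fold higher number from compound 3 to compound 4 (0.43 log units; beyond the scatter), and fluoro in place of hydrogen gives a 3.3-fold higher number from compound 2 to compound 4 (0.52 log units; beyond the scatter), so each change can pass the scatter when the other is present. Even so, the size of the bromo exchange cannot be said to depend on the core: the same change on two cores in this assay, a 1.4-fold higher number (0.16 log units; within the scatter) from compound 1 to compound 2 and a 2.7-fold higher number (0.43 log units; beyond the scatter) from compound 3 to compound 4, 1.9-fold (0.27 log units) apart, within the scatter of two such steps. The same holds for the fluoro change: the same change on two cores in this assay, a 1.8-fold higher number (0.24 log units; within the scatter) from compound 1 to compound 3 and a 3.3-fold higher number (0.52 log units; beyond the scatter) from compound 2 to compound 4, 1.9-fold (0.27 log units) apart, within the scatter of two such steps.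

The compounds shown leave open how a methoxy group or an amine would read at this place, para to a large group. They also leave open whether a longer chain in the shared core would alter either step.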